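Fluoro on the benzamide: from compound 3 to compound 4

The compounds below may be only part of what the source reports. "The series", "measured", "known", "first", "only" and "open" are said of these compounds alone.

Measured so far in the series:
compound 1, `C#CCNC1CCc2c(NCc3cccc(F)c3)cccc21`: 1860 nM
compound 2, `C#CCNC1CCc2c(SCc3ccc(F)cc3)cccc21`: 240 nM
compound 3, `C#CCNC1CCc2c(OCCc3cc(NC(=O)c4ccccc4)ccc3Cl)cccc21`: > 20000 nM

All three share the core of compound 1 and were tested in an assay on cells for inhibition of Amine oxidase [flavin-containing] B (Homo sapiens), read by fluorescence and Amplex Red, with stated times of 30 min and 15 min; a lower number here means a stronger inhibitor, a higher number a weaker inhibitor. Compound 1 gives 1860 nM, and compound 2 gives 240 nM. For compound 3 the assay reports only a limit, > 20000 nM. Compound 3 is thus the one of the three that sits at the limit of > 20000 nM in this assay, at which 1 of the 3 values shown sits, and no number places it against the other two.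

Compound 4, `C#CCNC1CCc2c(OCCc3cc(NC(=O)c4ccc(F)cc4)ccc3Cl)cccc21`, awaits measurement in this assay. It differs from compound 3 in one place: fluoro in place of hydrogen on an aromatic carbon. For the measured compounds named here, no measured pair differs in one place alone, so no measured step gives the size of such a change here. Because compound 3 gives only > 20000 nM, the outcome for compound 4 is expected to stay near that limit, and the step from a step that the limit leaves unreadable from compound 3 to compound 4 is expected to be none beyond the scatter. Compound 4 is estimated at 25000 nM, within a range from 8000 nM to 80000 nM, and most probably the assay will again report a limit.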

Compound 4, half-maximal inhibitory concentration: 5100 nM
Compound 4: middle estimate off by 4.9-fold (0.69 log units), on the high side; measured number below the stated range.
By their numbers in this assay, from the lowest: compound 2; then compound 1; then compound 4. At a limit, above all of these: compound 3.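

In this assay, for the compounds shown here, the change from phenyl to 4-fluorophenyl gives an at least 3.9-fold lower number from compound 3 to compound 4 (0.59 log units; beyond the scatter), the first single-place step that can be read. This position, para to a large group, therefore responds to a single fluoro, and compound 4 carries a measured number, 5100 nM, rather than a limit. Compound 3 stands at a limit of the assay, so the step fixes only a lower bound on the size of the change: the limit of > 20000 nM in this assay, at which 1 of the 4 values shown sits.

Open, as far as these compounds go, is whether fluoro is particular here or whether other groups at the same position, such as chloro, methoxy or a nitrile, would give a similar step. Also open, from the compounds shown here alone, is how the step would hold up with a longer chain in place of the ethyl-length link to the shared core.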